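Benzyl group swap in a bis(trifluoromethyl)benzenesulfonamide series

The source may report more compounds than this note shows. Statements on the series, on what has been measured and on what is new or still open speak of the compounds shown alone.

Measured compounds:
Compound 1 `COc1ccc(CNCCCNS(=O)(=O)c2cc(C(F)(F)F)cc(C(F)(F)F)c2)cc1OC` gives 1900 nM.
Compound 2 `O=S(=O)(NCCCNCc1ccc(-c2ccccc2)cc1)c1cc(C(F)(F)F)cc(C(F)(F)F)c1` gives 1700 nM.
Compound 3 `O=S(=O)(NCCCNCc1ccc(Cl)c(C(F)(F)F)c1)c1cc(C(F)(F)F)cc(C(F)(F)F)c1` gives 3500 nM.

In a functional assay on MCF7 cells (Homo sapiens) for inhibition, read by MTT assay, with a stated time of 72 h (on this read-out higher numbers stand for weaker inhibition of growth and lower numbers for stronger inhibition of growth), compound 3 stands highest of the three numbers. Its nearest is compound 1, and the step of a 1.8-fold higher number from compound 1 to compound 3 (0.27 log units; within the scatter) lies within the scatter, so the two cannot be ordered. Compound 2 lies further off, beyond the scatter. Compound 4 `O=S(=O)(NCCCNCc1ccc(Br)cc1)c1cc(C(F)(F)F)cc(C(F)(F)F)c1` has not yet been measured in this assay; it differs from compound 3 in one place: 4-bromophenyl in place of 4-chloro-3-(trifluoromethyl)phenyl on a saturated chain carbon bound to an amine nitrogen. Within the data shown here, the only measured step bearing on this change is a swap of the group on a saturated chain carbon bound to an amine nitrogen, a 1.8-fold higher number from compound 1 to compound 3 (0.27 log units; within the scatter), which stayed within the scatter. A further swap at that place is therefore expected to move the number little in this assay. Compound 4 is expected at 2500 nM, ranging from 1200 nM to 5500 nM. This amounts to an expected step of a 1.4-fold lower number from compound 3 to compound 4 (0.15 log units; within the scatter).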

Compound 4, concentration for 50% growth inhibition: 1900 nM
Beside the measured number, compound 4's estimate is 1.3-fold (0.12 log units) above it; the measured number falls inside the stated range.
By their numbers in this assay, from the lowest: compounds 2, 1, 4 and 3 (each within the scatter of the next, the first and the last beyond it).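

In this assay, a third group on the saturated chain carbon bound to an amine nitrogen again stays within the scatter: 4-bromophenyl gives a 1.8-fold lower number from compound 3 to compound 4 (0.27 log units; within the scatter) and no change at the digits printed from compound 1 to compound 4 (within the scatter). Bromo in place of phenyl on an aromatic carbon, a change at a second place, also stays within the scatter, with a 1.1-fold higher number from compound 2 to compound 4 (0.05 log units; within the scatter), so compound 4 cannot be ordered against any of the other three. No measurement at hand explains this. On these data alone, it remains open whether a carboxylic acid on that aromatic ring, or a longer chain in the shared core, would move the number beyond the scatter.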